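One Group Swap Seen on Two Different Cores

This account rests on a few compounds, and the source may have more. Where it says the series, first, only, none or still open, it means among the compounds named here.

Compound 1 `COc1ccc2cc(C(C)c3nnc4n3N=C(c3ccc(OC(F)(F)F)cc3)CS4)ccc2c1` gives 8800 nM in a functional assay on MCF7 cells (Homo sapiens) for inhibition, read by sulforhodamine B assay, with a stated time of 72 h; on this read-out higher numbers stand for weaker inhibition and lower numbers for stronger inhibition.
Compound 2 `COc1ccc(C2=Nn3c(nnc3C(C)c3ccc4cc(OC)ccc4c3)SC2)cc1` gives 6600 nM in this assay.
Compound 3 `CC(C)Cc1ccc(C(C)c2nnc3n2N=C(c2ccc(OC(F)(F)F)cc2)CS3)cc1` gives 1100 nM in this assay.

Compounds 1 and 2 share one core and differ in a single place: methyl in place of trifluoromethyl on an oxygen on an aromatic ring. In this assay this change made a 1.3-fold lower number from compound 1 to compound 2 (0.12 log units; within the scatter), so the two numbers cannot be told apart with confidence. Compound 3 is built on a different core; how its core differs from that of compound 1 is not broken down here. Compound 3 gives a clearly lower number than compound 1 and than compound 2, and both of those gaps lie beyond the usual scatter, so compound 3 is the strongest inhibitor of the three measured compounds.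

Compound 4 `COc1ccc(C2=Nn3c(nnc3C(C)c3ccc(CC(C)C)cc3)SC2)cc1` has not yet been measured. It differs from compound 3 in exactly one place: methyl in place of trifluoromethyl on an oxygen on an aromatic ring. This is the same change as from compound 1 to compound 2, and the surroundings of the place are described in identical words in both cases. For the measured compounds named here, the only evidence on this change is the step of a 1.3-fold lower number from compound 1 to compound 2 (0.12 log units; within the scatter), which stayed within the scatter, so the step expected from compound 3 to compound 4 is about a 1.2-fold lower number from compound 3 to compound 4 (0.09 log units; within the scatter), also within the scatter. Compound 4 is therefore expected to give roughly 900 nM, with a plausible range from 400 nM to 2000 nM.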

Compound 4, half-maximal inhibitory concentration: 5200 nM
For compound 4 the middle estimate is 5.8-fold (0.76 log units) below the measured one; the measured number lies above the stated range.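

In this assay, putting methyl in place of trifluoromethyl on the oxygen gave a 4.7-fold higher number from compound 3 to compound 4 (0.67 log units; beyond the scatter), so on the core of compound 3 this change clearly weakened inhibition. The same change did not carry over from one core to the other, as the two steps differ by more than repeated measurements would explain: the same change on two cores in this assay, a 1.3-fold lower number (0.12 log units; within the scatter) from compound 1 to compound 2 and a 4.7-fold higher number (0.67 log units; beyond the scatter) from compound 3 to compound 4, 6.3-fold (0.80 log units) apart, beyond the scatter of two such steps. For the compounds shown here, this shows that, in this small set, a step seen on one core cannot simply be added to a compound on another core, but with only two pairs it does not show why the steps differ, or which of them a further core would more closely follow.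

The compounds shown carry only trifluoromethoxy and methoxy at this place, so it stays open how a longer chain on the oxygen, such as ethoxy, or a free hydroxyl group would behave on either core. Only this assay is shown as well, so it also stays open whether the same difference between the two cores would appear in another cell line.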